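A Second Chloro Added to a Cytotoxic Core

This account rests on a few compounds, and the source may have more. Where it says the series, first, only, none or still open, it means among the compounds named here.

Measured compounds:
compound 1, `ClCc1cccc(Cn2cnc3c(Cl)ncnc32)c1`, 1900 nM
compound 2, `ClCc1cccc(Cn2cnc3c(Cl)nc(Cl)nc32)c1`, 2290 nM
compound 3, `ClCc1ccccc1Cn1cnc2ncnc(Cl)c21`, 4670 nM

Of the compounds shown here, three have been measured in a functional assay on NCI-H322M cells (Homo sapiens) for cytotoxicity, read by sulforhodamine B assay, with a stated time of 48 h; a higher number here means a weaker inhibitor of growth, a lower number a stronger inhibitor of growth. Compound 1 gives 1900 nM, and compound 2, which carries one more chloro group, gives 2290 nM. The change from compound 1 to compound 2 is chloro in place of hydrogen on an aromatic carbon, and it produced a 1.2-fold higher number from compound 1 to compound 2 (0.08 log units; within the scatter). Compound 3 has the same atoms as compound 1 joined differently; the difference between the two cores is not broken down here. Compound 3 gives 4670 nM, which stands as the highest of the three numbers, beyond the scatter from both compound 1 and compound 2.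

Compound 4 (`ClCc1ccccc1Cn1cnc2nc(Cl)nc(Cl)c21`) has not yet been measured. It differs from compound 3 by chloro in place of hydrogen on an aromatic carbon. Among the compounds with values here, this is the same change, at the same kind of place, as the one made from compound 1 to compound 2. On the core of compound 1 that change moved the number only within the scatter, as a 1.2-fold higher number from compound 1 to compound 2 (0.08 log units; within the scatter) shows. Within the data shown here, there is no measured pair on the core of compound 3 to test whether it behaves alike, so the expectation rests on that single earlier step alone. Among the measured compounds shown here, compound 4 is therefore expected to sit close to compound 3, with a step of about a 1.2-fold higher number from compound 3 to compound 4 (0.06 log units; within the scatter) in this assay, because a 1.2-fold higher number from compound 1 to compound 2 (0.08 log units; within the scatter) was the only precedent. The estimate for compound 4 in this assay is 5400 nM, with a likely range from 2500 nM to 11500 nM.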

Compound 4, concentration for 50% growth inhibition: 4260 nM
Estimate against measurement, compound 4: 1.3-fold (0.10 log units) above; measured number inside the range.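

In this assay, chloro in place of hydrogen on an aromatic carbon, between two ring nitrogen atoms, gave a 1.1-fold lower number from compound 3 to compound 4 (0.04 log units; within the scatter). Set beside the earlier step, the change behaves alike on both cores, with neither step leaving the scatter and no difference between them that can be told from it: the same change on two cores in this assay, a 1.2-fold higher number (0.08 log units; within the scatter) from compound 1 to compound 2 and a 1.1-fold lower number (0.04 log units; within the scatter) from compound 3 to compound 4, 1.3-fold (0.12 log units) apart, within the scatter of two such steps This shows that, in this one cell assay, the change carried across without a readable effect on either core, but it rests on only two matched pairs and does not show that the change would stay silent on any further core or in another kind of test, nor does it say why the number held.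

The compounds shown leave open whether an amine or a methoxy group in place of this chloro, between two ring nitrogen atoms, would move the number beyond the scatter, since chloro and hydrogen are the only two groups seen there. They also leave open what a carboxylic acid or a longer chain elsewhere on these compounds would do, and whether such a change would carry from one core to the other as this one did.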